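A few compounds are considered here, and "the series" means these few. Any claim that something is new, unique, unknown or untested is made for them only; others in the source may bear on it.

Measured so far:
compound 1 `Cc1ccc(S(=O)(=O)Nc2ccc3oc(-c4ccccc4)nc3c2)cc1`: 75000 nM
compound 2 `O=S(=O)(Nc1ccc(-c2nc3ccccc3o2)cc1)c1ccc(F)c(C(F)(F)F)c1`: 82000 nM
compound 3 `O=S(=O)(Nc1ccc(-c2nc3ccccc3o2)cc1)c1cccs1`: > 100000 nM

The readout here is an ADME assay on HEK293 cells (Homo sapiens) for cytotoxicity, read by resazurin assay, with a stated time of 48 h (a lower number here means that less compound is tolerated, a higher number that more compound is tolerated), a measure of how much compound the cells tolerate before they stop converting the dye. Compound 1 gives 75000 nM. Compound 2 gives 82000 nM, a number so close to that of compound 1 that the two cannot be told apart. Compound 3 gives only a limit, > 100000 nM, meaning the assay ran out of range before a number could be read; this is the limit described as the limit of > 100000 nM in this assay, at which 1 of the 3 values shown sits.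

Compound 4 `O=S(=O)(Nc1ccc2oc(-c3ccccc3)nc2c1)c1ccc(O)cc1` is the next compound to be measured in this assay. It differs from compound 1 in one spot: hydroxy in place of methyl on an aromatic carbon. Among the measured compounds shown here, no measured pair in this set makes a comparable change, so the expectation rests only on the three numbers above. Because all of them sit high, with compound 3 at the limit (the limit of > 100000 nM in this assay, at which 1 of the 3 values shown sits), no step beyond the scatter is expected from compound 1 to compound 4. The estimated step of a 1.2-fold higher number from compound 1 to compound 4 (0.08 log units; within the scatter) is small. Compound 4 is therefore expected to give about 90000 nM, somewhere between 40000 nM and 200000 nM, with a fair chance that the assay again reports only a limit.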

Compound 4, half-maximal cytotoxic concentration: > 100000 nM
Compound 4: no number, only a limit; the forecaster's own chance of this, stated with the estimate: 40%; middle value at least 1.1-fold (0.04 log units) away from the limit.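

Among the compounds shown here, replacing methyl with hydroxy at this position gives the first comparison here between two compounds that differ in one place, and this assay reads it as an at least 1.3-fold higher number from compound 1 to compound 4 (0.12 log units; that floor lies within the scatter). Compound 4 gives > 100000 nM, which is a limit and not a number, leaving that step a floor whose true size cannot be read. Even so, a hydroxy on this aromatic carbon, para to a large group, shows no sign that less compound is tolerated, and the result joins the values sitting at the top of the readable range: the limit of > 100000 nM in this assay, at which 2 of the 4 values shown sit.

On these data alone, whether an amine, a methoxy group or a carboxylic acid at the same position would bring the number down into the readable range remains open. Nor do the compounds shown tell whether the same swap on a different core would give the same result.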